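Piperazine in place of tetrazolylthio on the amide chain

The source may hold more compounds than are shown below. What is called first, only, known or untested is meant among the compounds shown, and "the series" means these compounds.

Among the measured compounds shown here, compound 2 `Cn1nnnc1SCC(=O)Nc1ccc(-c2nc(-c3ccccc3)c(-c3ccccc3)n2C)cc1` gives 21.9% in a functional assay on MCF7 cells (Homo sapiens) for cytotoxicity, read by MTT assay, with a stated time of 24 h, tested at 0.64 ug/mL (on this read-out lower numbers stand for a weaker effect and higher numbers for a stronger effect at the one concentration tested), the higher of the two numbers measured so far, while compound 1 `Cn1c(-c2ccc(NC(=O)CSc3nc4ccccc4s3)cc2)nc(-c2ccccc2)c1-c1ccccc1` gives 0.9%. For the measured compounds named here, the only measured step, a number 21 percentage points higher from compound 1 to compound 2 (beyond the scatter), concerns an exchange on the sulfur and does not bear on the present change. Compound 3 `CCN1CCN(CC(=O)Nc2ccc(-c3nc(-c4ccccc4)c(-c4ccccc4)n3C)cc2)CC1` differs from compound 2 by 4-ethylpiperazin-1-yl in place of (1-methyl-1H-tetrazol-5-yl)sulfanyl on a saturated chain carbon bound to a carbonyl carbon. Going by the values given here, no measured step covers this exchange, so the step of a number 6.9 percentage points lower from compound 2 to compound 3 (within the scatter) is expected to stay within the usual scatter, with wide uncertainty in either direction. Compound 3 is therefore estimated at 15%, within a range of 0% to 40%.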

Compound 3, a percentage reported as activity, at one concentration (the size of the read-out at that concentration, not a potency): 4.7%
For compound 3 the middle estimate is 10.3 percentage points above the measured one; measured number inside the range.
By their numbers in this assay, from the lowest: compounds 1 and 3 (each within the scatter of the next); then compound 2.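

At the saturated chain carbon bound to a carbonyl carbon, this assay now covers a group without sulfur: 4-ethylpiperazin-1-yl in place of (1-methyl-1H-tetrazol-5-yl)sulfanyl gives a number 17.2 percentage points lower from compound 2 to compound 3 (beyond the scatter). The same group in place of (1,3-benzothiazol-2-yl)sulfanyl gives a number 3.8 percentage points higher from compound 1 to compound 3 (within the scatter); among these three compounds, only compound 2 stands apart. No measured evidence bears on the cause of either step. Open, on these data alone, is whether morpholine or unsubstituted piperazine in place of 4-ethylpiperazin-1-yl would stay level with compound 3 or approach compound 2.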